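Carboxy to methoxycarbonyl on the shared core

The compounds below may be only part of what the source reports. "The series", "measured", "known", "first", "only" and "open" are said of these compounds alone.

In a functional assay on HCT-116 cells (Homo sapiens) for antiproliferative activity (on this read-out higher numbers stand for weaker inhibition of growth and lower numbers for stronger inhibition of growth), compound 3 (`COc1ccc(OC)c(C#Cc2ccc(OC)c(C(=O)O)c2)c1`) gives 32300 nM, within the scatter of compound 2 (`COC(=O)c1cc(/C=C\c2cc(OC)ccc2OC)ccc1OC`) at 20100 nM. Compound 1 (`CCCCCCNC(=O)c1cc(C#Cc2cc(OC)ccc2OC)ccc1OC`) gives 6900 nM, a clearly lower number. Compound 4 (`COC(=O)c1cc(C#Cc2cc(OC)ccc2OC)ccc1OC`) has methyl in place of hydrogen on an oxygen next to a carbonyl group, carboxy to methoxycarbonyl (methyl in place of hydrogen on an oxygen next to a carbonyl group). The closest measured step changes the same carbonyl substituent: a 4.7-fold higher number from compound 1 to compound 3 (0.67 log units; beyond the scatter), with hydroxy in place of hexylamino. Compound 2 also carries methoxycarbonyl but differs elsewhere in the core, so it gives only loose support. Within the data shown here, a modest move toward a lower number is expected, no larger than that step. The expected change is a 2.0-fold lower number from compound 3 to compound 4 (0.31 log units; beyond the scatter). Compound 4 is estimated at 16000 nM, with an expected range of 6000 nM to 40000 nM.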

Compound 4, concentration for 50% growth inhibition: 37700 nM
Estimate against measurement, compound 4: 2.4-fold (0.37 log units) below; the range from low to high includes it.
By their numbers in this assay, from the lowest: compound 1; then compounds 2, 3 and 4 (each within the scatter of the next).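

Methyl on this oxygen leaves the number unmoved: swapping carboxy for methoxycarbonyl gives a 1.2-fold higher number from compound 3 to compound 4 (0.07 log units; within the scatter), so the free acid hydrogen makes no readable difference here. Hexylamino alone stands apart at this carbonyl carbon, with a 5.5-fold higher number from compound 1 to compound 4 (0.74 log units; beyond the scatter) and with a 4.7-fold higher number from compound 1 to compound 3 (0.67 log units; beyond the scatter), while hydroxy and methoxy cannot be told apart. Nothing available explains this difference.

Still open, going by these compounds, is whether the lower number of compound 1 depends on the amide link or on the chain: methylamino, a plain amino group or a longer alkyl chain on the same carbonyl carbon would separate these.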